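This account rests on a few compounds, and the source may have more. Where it says the series, first, only, none or still open, it means among the compounds named here.

Among the compounds with values here, compound 2 `O=C(Nc1ccnnc1)c1cc(N2CCC(O)CC2)ccc1OCc1ccccc1` gives 39.8 nM in an assay on Sf9 cells for inhibition of Leucine-rich repeat serine/threonine-protein kinase 2 (Homo sapiens), read by TR-FRET, with stated times of 30 min and 2 h (on this read-out higher numbers stand for weaker inhibition and lower numbers for stronger inhibition), the highest of the two numbers measured so far; compound 1 `C[C@@H]1CN(c2ccc(OCc3ccccc3)c(C(=O)Nc3ccnnc3)c2)C[C@H](C)O1` gives 20 nM. Compound 3 `O=C(Nc1ccnnc1)c1cc(N2CCNCC2)ccc1OCc1ccccc1` carries the change (piperazin-1-yl in place of 4-hydroxypiperidin-1-yl on an aromatic carbon). Within the data shown here, the one measured step that bears on it is the earlier exchange of the saturated ring on the same aromatic carbon, a 2.0-fold higher number from compound 1 to compound 2 (0.30 log units; within the scatter), a step within the scatter. For compound 3 in this assay, then, no step beyond the scatter is expected, an estimated 1.0-fold higher number from compound 2 to compound 3 (0.00 log units; within the scatter). Compound 3 is expected to give 40 nM, within a range of 15 nM to 110 nM.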

Compound 3, half-maximal inhibitory concentration in the Leucine-rich repeat serine/threonine-protein kinase 2 assay: 15.9 nM
For compound 3 the middle estimate is 2.5-fold (0.40 log units) above the measured one; the range from low to high includes it.
By their numbers in the Leucine-rich repeat serine/threonine-protein kinase 2 assay, from the lowest: compounds 3, 1 and 2 (each within the scatter of the next, the first and the last beyond it).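

In the Leucine-rich repeat serine/threonine-protein kinase 2 assay, this position now gives a step beyond the scatter, a 2.5-fold lower number from compound 2 to compound 3 (0.40 log units; beyond the scatter), while a 1.3-fold lower number from compound 1 to compound 3 (0.10 log units; within the scatter) shows that piperazin-1-yl and 2,6-dimethylmorpholin-4-yl remain within the scatter of each other. In a physicochemical assay for lipophilicity, at pH 7.4 (on this read-out higher numbers stand for higher lipophilicity and lower numbers for lower lipophilicity), compound 2 gives 3.2 and compound 3 gives 1.9. The same exchange also lowers lipophilicity, with no rise in the number in the Leucine-rich repeat serine/threonine-protein kinase 2 assay: the measured distribution coefficient of compound 2, 3.2, and of compound 3, 1.9, a number 1.30 log units lower (beyond the scatter)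

The compounds shown cannot separate the contribution of the entering ring nitrogen from that of the departing hydroxyl. As far as these compounds go, how a methyl or acetyl group on the piperazine nitrogen would read in either measure remains open.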